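The source may report more compounds than this note shows. Statements on the series, on what has been measured and on what is new or still open speak of the compounds shown alone.

Compound 2 `CCS(=O)(=O)Nc1cc(-c2ccc3ncnc(Nc4ccc(OC)c(OC)c4)c3c2)cnc1OC` and compound 1 `CCS(=O)(=O)Nc1cc(-c2ccc3ncnc(Nc4ccc(F)cc4F)c3c2)cnc1OC` share one core and differ only in the aryl group on the amine nitrogen. In a functional assay on BT-549 cells (Homo sapiens) for cytotoxicity, read by sulforhodamine B assay, with a stated time of 72 h (a lower number here means a stronger inhibitor, a higher number a weaker inhibitor), compound 1 gives 2480 nM, and compound 2 gives 2590 nM; the swap a 1.0-fold higher number from compound 1 to compound 2 (0.02 log units; within the scatter) left the two within the usual scatter of each other. Compound 3 `CCS(=O)(=O)Nc1cc(-c2ccc3ncnc(Nc4ccc(OC)c(Cl)c4)c3c2)cnc1OC` keeps that core and differs from compound 2 by chloro in place of methoxy on an aromatic carbon. Going by the values given here, the one measured step, a change of the same aryl ring, was flat, so for compound 3 an essentially unchanged result is expected, a 1.2-fold lower number from compound 2 to compound 3 (0.07 log units; within the scatter), giving an estimate of 2200 nM with a range from 900 nM to 5500 nM.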

Compound 3, half-maximal inhibitory concentration: 2470 nM
Compound 3: middle estimate off by 1.1-fold (0.05 log units), on the low side; the range from low to high includes it.
By their numbers in this assay, from the lowest: compounds 3, 1 and 2 (each within the scatter of the next).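

Swapping methoxy for chloro on this aromatic carbon, ortho to a methoxy group, changes a single ring substituent rather than the whole aryl group, and in this assay the result lies within the scatter (a 1.0-fold lower number from compound 2 to compound 3 (0.02 log units; within the scatter)). The wider swap of the aryl group on the nitrogen also lies within the scatter (a 1.0-fold lower number from compound 1 to compound 3 (0.00 log units; within the scatter)), so all three aryl groups give matching numbers. Nothing available explains this match.

Still open, on these data alone, is whether an amine or a carboxylic acid at this carbon would shift the number. As far as these compounds go, a longer chain in place of the remaining methoxy is equally open.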